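The source may report more compounds than this note shows. Statements on the series, on what has been measured and on what is new or still open speak of the compounds shown alone.

Measured compounds:
- compound 1 `Nc1ccc(CNC(=O)CC2c3ccccc3N=C(N3CCCCC3)N2c2ccccc2)cc1`: 8.9%
- compound 2 `CCN1C(N2CCCCC2)=Nc2ccccc2C1CC(=O)NCc1ccccc1`: 9.3%

Both numbers come from an assay on HEK293 cells for inhibition of Voltage-dependent N-type calcium channel subunit alpha-1B (Homo sapiens), tested at 10 uM; on this read-out higher numbers stand for more inhibition at the one concentration tested (going by the name of the read-out) and lower numbers for less inhibition. In this assay compound 1 gives 8.9% and compound 2 gives 9.3%. Compound 1 holds the smaller of the two figures, yet the gap to compound 2 lies within the usual scatter, so the pair is read as indistinguishable: neither compound shows appreciable inhibition at the single concentration tested.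

Compound 3 `Cc1ccc(S(=O)(=O)Nc2ccc(CNC(=O)CC3c4ccccc4N=C(N4CCCCC4)N3c3ccccc3)cc2)cc1` follows from compound 1 by one change: (4-methylphenyl)sulfonyl in place of hydrogen on a nitrogen on an aromatic ring. Going by the values given here, no step between measured compounds is available, so the size and direction of this change cannot be read from data already in hand; a step of no more than the scatter is the plainest expectation, with a modest rise kept open.

Compound 3 is therefore expected to give 15% in this assay, within 2% to 38%, an estimated step of a number 6.1 percentage points higher from compound 1 to compound 3 (within the scatter).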

Compound 3, a percentage reported as inhibition, at one concentration (the size of the read-out at that concentration, not a potency): 14.1%
For compound 3 the middle estimate is 0.9 percentage points above the measured one; the range from low to high includes it.
By their numbers in this assay, from the lowest: compounds 1, 2 and 3 (each within the scatter of the next).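

Going by these compounds alone, replacing hydrogen with (4-methylphenyl)sulfonyl on the nitrogen on an aromatic ring gives a number 5.2 percentage points higher from compound 1 to compound 3 (within the scatter) in this assay, the first single-place comparison. At this position, the amino to ((4-methylphenyl)sulfonyl)amino change adds 10 heavy atoms and one six-membered aromatic ring of carbon only, yet compound 3 cannot be told apart from compound 1 on this read-out. Nothing available bears on why this change leaves the read-out within the scatter.

As far as these compounds go, whether a smaller methylsulfonyl or an acetyl on this nitrogen, or a carboxylic acid in place of the amino group, would give a step beyond the scatter remains open. From the compounds shown here alone, with one concentration per compound, the potency of compound 1 and compound 3 also remains open.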